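From 3-bromophenyl to 4-bromophenyl

The source may hold more compounds than are shown below. What is called first, only, known or untested is meant among the compounds shown, and "the series" means these compounds.

In a functional assay on HepG2 cells (Homo sapiens) for inhibition, read by MTT assay, with a stated time of 48 h (a higher number here means a weaker inhibitor, a lower number a stronger inhibitor), compound 1 (`COc1ccccc1-c1csc(N/N=C/c2ccc(F)c(F)c2)n1`) gives > 100000 nM as a limit of the assay, not a number. Among the compounds with values here, compound 2 (`Fc1ccc(/C=N/Nc2nc(-c3cccc(Br)c3)cs2)cc1F`) gives 16700 nM as the only true number so far. Within the data shown here, the one measured step is an at least 5.9-fold lower number from compound 1 to compound 2 (0.77 log units; beyond the scatter) with 3-bromophenyl in place of 2-methoxyphenyl on an aromatic carbon.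

Compound 3 (`Fc1ccc(/C=N/Nc2nc(-c3ccc(Br)cc3)cs2)cc1F`) has the same atoms as compound 2, joined differently (4-bromophenyl in place of 3-bromophenyl on an aromatic carbon). Here 4-bromophenyl stands in place of 3-bromophenyl. The measured step exchanged two different groups, whereas this change only relocates the bromine within the same group, so that step gives little guidance on size or direction. The best expectation is therefore no change beyond the scatter, with neither direction favoured, and the expected step is a 1.1-fold lower number from compound 2 to compound 3 (0.05 log units; within the scatter) in this estimate. For compound 3 the estimated value is 15000 nM (expected range 5000 nM to 50000 nM).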

Compound 3, half-maximal inhibitory concentration: > 100000 nM
Compound 3: a limit, no number; the forecaster's own chance of this, stated with the estimate: 15%; middle value at least 6.6-fold (0.82 log units) from the limit.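

Moving the bromine within the same group gives an at least 5.9-fold higher number from compound 2 to compound 3 (0.77 log units; beyond the scatter) in this assay, so at this position on the shared core, 3-bromophenyl and 4-bromophenyl are not interchangeable, even though the two compounds have the same atoms. Going by these compounds, compound 3 gives > 100000 nM, which is a limit and not a number, so the step has a direction and a smallest size, but its full size stays unknown. The step between compound 1 and compound 3 cannot be read, and compound 2 alone gives a true number here: the limit of > 100000 nM in this assay, at which 2 of the 3 values shown sit.

On these data alone, it remains open whether bromine itself matters at this position or whether a phenyl group carrying chlorine, an amine or a carboxylic acid in its place would also give a true number. A single true number also cannot show how far any such change would move the result.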